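Dibutylamino Tail in Place of a Chain Methyl

The compounds below may be only part of what the source reports. "The series", "measured", "known", "first", "only" and "open" are said of these compounds alone.

Three compounds of one series were measured in a functional assay on LNCaP cells (Homo sapiens) for antiproliferative activity, read by WST assay, with a stated time of 3 days; on this read-out higher numbers stand for weaker inhibition and lower numbers for stronger inhibition. Compound 1 `CCOc1c(-c2cc(OC)c(OC)c(OC)c2)oc2ccccc2c1=O` gives 5400 nM, compound 2 `CCCCCCOc1c(-c2cc(OC)c(OC)c(OC)c2)oc2ccccc2c1=O` gives 19600 nM, and compound 3 `CCCN(CCC)CCCCCOc1c(-c2cc(OC)c(OC)c(OC)c2)oc2ccccc2c1=O` gives 7600 nM. Compound 2 stands highest of the three numbers: a 3.6-fold higher number from compound 1 to compound 2 (0.56 log units; beyond the scatter) and a 2.6-fold lower number from compound 2 to compound 3 (0.41 log units; beyond the scatter), both beyond the scatter, so compound 2 is the weakest inhibitor among them. Compound 4 `CCCCN(CCCC)CCCCCOc1c(-c2cc(OC)c(OC)c(OC)c2)oc2ccccc2c1=O` has not yet been measured. It differs from compound 2 by dibutylamino in place of methyl on a saturated chain carbon, five bonds along the chain from an oxygen on an aromatic ring. The step that bears most directly on this change is the one in which a dipropylamino group entered at the same place, a 2.6-fold lower number from compound 2 to compound 3 (0.41 log units; beyond the scatter), a modest lowering. Dibutylamino is the longer relative of dipropylamino, and the step of a 3.6-fold higher number from compound 1 to compound 2 (0.56 log units; beyond the scatter) showed that added chain length on its own raised the number, so the gain may be somewhat smaller. The step is expected to read a 2.2-fold lower number from compound 2 to compound 4 (0.34 log units; beyond the scatter). Compound 4 is estimated at 9000 nM, with a range from 4000 nM to 20000 nM.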

Compound 4, half-maximal inhibitory concentration: 7800 nM
For compound 4 the middle estimate is 1.2-fold (0.06 log units) above the measured one; low and high end bracket the measured number.
By their numbers in this assay, from the lowest: compounds 1, 3 and 4 (each within the scatter of the next); then compound 2.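

In this assay, dibutylamino at this place, on a saturated chain carbon five bonds along the chain from an oxygen on an aromatic ring, also lowers the number relative to the unsubstituted chain of compound 2 (a 2.5-fold lower number from compound 2 to compound 4 (0.40 log units; beyond the scatter)), so this effect is no longer confined to dipropylamino. Lengthening the chains on the nitrogen from propyl to butyl gives no readable difference (a 1.0-fold higher number from compound 3 to compound 4 (0.01 log units; within the scatter)), and the tailed compound also remains within the scatter of compound 1, which lacks the tail (a 1.4-fold higher number from compound 1 to compound 4 (0.16 log units; within the scatter)). Nothing given here accounts for these results.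

From the compounds shown here alone, it remains open how a smaller amine such as dimethylamino or a cyclic one such as piperidine would read at this place. A shorter or longer chain between the ring oxygen and the nitrogen is equally unresolved.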